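This account rests on a few compounds, and the source may have more. Where it says the series, first, only, none or still open, it means among the compounds named here.

Working notes on the series in a functional assay on HCT-116 cells (Homo sapiens) for cytotoxicity, read by MTT assay, with a stated time of 48 h; a higher number here means a weaker inhibitor, a lower number a stronger inhibitor.

Of the compounds shown here, two carry a measured number so far. Compound 1 `CNC(=O)c1cc(Oc2cccc(NC(=S)Nc3ccc(OC(F)(F)F)cc3)c2)ccn1` gives 33800 nM in this assay, and compound 2 `CC(C)NC(=O)c1cc(Oc2cccc(NC(=S)Nc3ccc(OC(F)(F)F)cc3)c2)ccn1` gives 18100 nM. For the measured compounds named here, the only step between measured compounds that differ in one place is a 1.9-fold lower number from compound 1 to compound 2 (0.27 log units; within the scatter), so the two values stand within the scatter of each other and neither can be called the stronger. Going by the values given here, compound 2 holds the lowest of the two numbers, with compound 1 as its only neighbour.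

Compound 3 `O=C(c1cc(Oc2cccc(NC(=S)Nc3ccc(OC(F)(F)F)cc3)c2)ccn1)N1CCCC1` is not yet measured. Its change from compound 2 is pyrrolidin-1-yl in place of isopropylamino on a carbonyl carbon. Among the compounds with values here, no measured step bears directly on this change: the one step available, from compound 1 to compound 2, swaps one alkyl group for another on the amide-type nitrogen and stayed within the scatter, while the step to compound 3 closes that nitrogen into a ring. With nothing in the series showing a shift beyond the scatter on this part of the shared core, no step beyond the scatter is expected for a 1.1-fold higher number from compound 2 to compound 3 (0.04 log units; within the scatter). For compound 3 the estimate in this assay is 20000 nM, within a range of 7000 nM to 60000 nM.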

Compound 3, half-maximal inhibitory concentration: 17800 nM
For compound 3 the middle estimate is 1.1-fold (0.05 log units) above the measured one; the measured number falls inside the stated range.
By their numbers in this assay, from the lowest: compounds 3, 2 and 1 (each within the scatter of the next).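

In this assay, for the compounds shown here, the new step (a 1.0-fold lower number from compound 2 to compound 3 (0.01 log units; within the scatter)) is the first to take away the amide hydrogen and close the group on the carbonyl carbon into a ring, and it stays within the scatter, as does the step from the other side (a 1.9-fold lower number from compound 1 to compound 3 (0.28 log units; within the scatter)). Methylamino, isopropylamino and pyrrolidin-1-yl on this carbonyl carbon therefore all stand within the scatter of one another, so in these three compounds neither the hydrogen-bond donor of the open amides nor the five-membered ring separates the values. Nothing measured offers an explanation for this flat result.

Open, on these data alone, is whether any group on this carbonyl carbon gives a step beyond the scatter, for example a carboxylic acid, a morpholin-4-yl ring, a longer alkyl chain or a chain ending in a dimethylamino group. The rest of the shared core is the same in all three compounds, so these values say nothing about how changes elsewhere on it would read in this assay.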